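From thiophen-2-yl to pyridin-3-yl on a shared core

The source may report more compounds than this note shows. Statements on the series, on what has been measured and on what is new or still open speak of the compounds shown alone.

Compound 1 `Oc1cccc(-c2cc(-c3cccs3)cc(-c3cccc(O)c3)n2)c1` and compound 2 `Oc1ccc(-c2cc(-c3cccs3)cc(-c3cccc(O)c3)n2)cc1` share one core and differ only in where the hydroxyl sits on one of the two aryl groups. In a functional assay on HeLa cells (Homo sapiens) for cytotoxicity, read by CCK-8 assay (a higher number here means a weaker inhibitor, a lower number a stronger inhibitor), compound 1 gives 1690 nM, and compound 2 gives 4140 nM. Within the data shown here, the step of a 2.4-fold higher number from compound 1 to compound 2 (0.39 log units; beyond the scatter) is the only measured comparison in this set. Compound 1 stands at the lower of the two numbers and is thus the stronger inhibitor of the pair. Compound 3 `Oc1cccc(-c2cc(-c3cccnc3)cc(-c3cccc(O)c3)n2)c1` keeps both 3-hydroxyphenyl groups of compound 1 and changes the third substituent: pyridin-3-yl in place of thiophen-2-yl on an aromatic carbon. Among the measured compounds shown here, no measured step touches this part of the molecule; the single known step concerns only the hydroxyl placement and says nothing about exchanging one small aromatic ring for another. The expectation for compound 3 in this assay is therefore a step of about a 1.2-fold higher number from compound 1 to compound 3 (0.07 log units; within the scatter), with no direction that should clearly exceed the scatter. The estimate for compound 3 is 2000 nM, with a range from 700 nM to 6000 nM.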

Compound 3, half-maximal inhibitory concentration: > 50000 nM
Compound 3 ended at the assay's limit; the forecaster's own chance of this, stated with the estimate: 5%; middle value at least 25-fold (1.39 log units) away from the limit.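

Exchanging thiophen-2-yl for pyridin-3-yl gives an at least 29-fold higher number from compound 1 to compound 3 (1.47 log units; beyond the scatter) in this assay, a large step, whereas moving one hydroxyl gave the modest 2.4-fold higher number from compound 1 to compound 2 (0.39 log units; beyond the scatter). So the substituent opposite the ring nitrogen, with both 3-hydroxyphenyl groups unchanged, matters a great deal in this series, even though the two rings have the same counts of hydrogen-bond donors and acceptors, and those counts alone do not tell them apart here. The value of compound 3, > 50000 nM, is a limit of this assay and not a number: the limit of > 50000 nM in this assay, at which 1 of the 3 values shown sits.

The two rings differ in size and in their hetero atom, sulfur in one and nitrogen in the other, and these compounds cannot show which of those differences matters, or whether neither does. Still open, from the compounds shown here alone, is how this position would respond to a plain phenyl ring, to thiophen-3-yl, to pyridin-2-yl or pyridin-4-yl with the ring nitrogen placed elsewhere, or to a non-aromatic group such as an amine or a carboxylic acid.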